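Swapping an Acid for an Alcohol on a Weak Antagonist

The compounds below may be only part of what the source reports. "The series", "measured", "known", "first", "only" and "open" are said of these compounds alone.

Compound 2, `O=C(O)CCN1CCC[C@H]1c1nc(-c2ccc3ccccc3c2)no1`, was tested in an assay on HepG2 cells for antagonist activity at Bile acid receptor (Homo sapiens), read by a luciferase reporter (on this read-out lower numbers stand for stronger inhibition and higher numbers for weaker inhibition), where compound 2 gives 28400 nM. Within the data shown here, only one other compound has a number here: compound 1, `O=C(O)CCCN1CCC(c2nc(-c3ccc4ccccc4c3)no2)CC1`, which in this assay gives 25700 nM. The two values lie within the usual scatter of each other, so neither can be called the stronger, and both sit at the weak end of what such a test resolves.

Compound 3, `OCCCCN1CCC[C@H]1c1nc(-c2ccc3ccccc3c2)no1`, has not yet been measured. It differs from compound 2 in one place: 2-hydroxyethyl in place of carboxy on a saturated chain carbon, two bonds along the chain from an amine nitrogen in a ring. Among the measured compounds shown here, no measured pair shows this kind of exchange, so there is no step to lean on. Compound 3 is therefore expected to land close to compound 2, with an estimated step of a 1.2-fold higher number from compound 2 to compound 3 (0.09 log units; within the scatter) that need not exceed the scatter. The estimate for compound 3 in this assay is 35000 nM, within a range from 10000 nM to 100000 nM.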

Compound 3, half-maximal inhibitory concentration: 33800 nM
Beside the measured number, compound 3's estimate is 1.0-fold (0.02 log units) above it, and the stated range covers the measured number.
By their numbers in this assay, from the lowest: compounds 1, 2 and 3 (each within the scatter of the next).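

Among these compounds, putting 2-hydroxyethyl in place of carboxy gives a 1.2-fold higher number from compound 2 to compound 3 (0.08 log units; within the scatter) in this assay, the first exchange at a single place that can be read in this set. At this place on the chain, then, the carboxylic acid of compound 2 is not needed to hold the number where it stands, and an end carrying an alcohol reads the same within the resolution of the test, though neither brings the number out of the weak range. Nothing at hand explains why the two ends read alike.

From the compounds shown here alone, whether an amine or a primary amide at this place, or a longer chain ending in an alcohol, would shift the number beyond the scatter stays open. So does whether the same exchange would read alike on the core of compound 1.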